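Methoxy on the cinnamaldehyde ring of a benzyloxy series

The source may report more compounds than this note shows. Statements on the series, on what has been measured and on what is new or still open speak of the compounds shown alone.

Going by the values given here, compound 1 `O=C/C=C/c1ccccc1OCc1ccccc1` gives the highest of the two numbers measured so far: in a functional assay on cells (Neutrophil, Rattus norvegicus, strain Sprague-Dawley) for inhibition (on this read-out higher numbers stand for weaker inhibition and lower numbers for stronger inhibition), compound 1 gives 6400 nM. Its nearest neighbour is compound 2 `O=C/C=C/c1ccccc1OCc1ccccc1F`, which in this assay gives 3300 nM; the step of a 1.9-fold lower number from compound 1 to compound 2 (0.29 log units; within the scatter) is the only one recorded, and it concerns a fluoro group on the benzyl ring rather than the ring that carries the 2-formylethenyl group. Compound 3 `COc1ccc(OCc2ccccc2)c(/C=C/C=O)c1` differs from compound 1 by methoxy in place of hydrogen on an aromatic carbon. Among the compounds with values here, no measured step touches that ring, so the expectation for compound 3 rests on the general flatness seen so far: the step of a 1.3-fold lower number from compound 1 to compound 3 (0.11 log units; within the scatter) is expected to stay within the scatter. Compound 3 is therefore estimated at 5000 nM in this assay, with a range from 1500 nM to 16000 nM.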

Compound 3, half-maximal inhibitory concentration: 2600 nM
Compound 3: middle estimate off by 1.9-fold (0.28 log units), on the high side; measured number inside the range.
By their numbers in this assay, from the lowest: compounds 3, 2 and 1 (each within the scatter of the next, the first and the last beyond it).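

In this assay, going by these compounds alone, the step of a 2.5-fold lower number from compound 1 to compound 3 (0.39 log units; beyond the scatter) is the first recorded change on the ring that carries the 2-formylethenyl group, and it shows that this ring responds to substitution: methoxy in place of hydrogen, meta to that group and para to the group of 8 heavy atoms, shifts the number modestly beyond the scatter. Within the data shown here, the only earlier step, a 1.9-fold lower number from compound 1 to compound 2 (0.29 log units; within the scatter) concerned the benzyl ring and stayed within the scatter, so the flatness seen there does not carry over to this position. Nothing given here accounts for the shift.

The compounds shown leave open whether the shift belongs to methoxy itself or to any group at this place, as a hydroxyl, an amine, a carboxylic acid or a longer chain such as ethoxy could tell. They also leave open how the other aromatic carbons of this ring respond.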